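The compounds below may be only part of what the source reports. "The series", "measured", "known", "first", "only" and "open" are said of these compounds alone.

Working notes on the series. In a functional assay (Homo sapiens) for inhibition, with a stated time of 72 h (a lower number here means a stronger inhibitor, a higher number a weaker inhibitor), compound 1 `COc1cc(C(=O)c2ccc3[nH]ccc3c2)cc(OC)c1OC` gives 111 nM and compound 2 `COc1cc(C(=O)c2ccc3c(ccn3CC(=O)O)c2)cc(OC)c1OC` gives 476 nM. Compound 3 `COc1cc(C(=O)c2ccc3c(ccn3CCC(=O)O)c2)cc(OC)c1OC` gives only a limit, > 10000 nM, which puts it at the weak end of the three: the limit of > 10000 nM in this assay, at which 1 of the 3 values shown sits.

Compound 4 `COc1cc(C(=O)c2ccc3c(ccn3CCN(C)C)c2)cc(OC)c1OC` has dimethylamino in place of carboxy on a saturated chain carbon, two bonds along the chain from an aromatic nitrogen. Going by the values given here, no measured step makes this exchange. Among the compounds with values here, three steps bear on it indirectly, all at that same aromatic nitrogen: a 4.3-fold higher number from compound 1 to compound 2 (0.63 log units; beyond the scatter), an at least 90-fold higher number from compound 1 to compound 3 (1.95 log units; beyond the scatter) and an at least 21-fold higher number from compound 2 to compound 3 (1.32 log units; beyond the scatter). These three compounds cannot separate the loss seen with compound 3 into a share for the carboxy and a share for the chain length.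

With compound 2 as the guide, through the size of a 4.3-fold higher number from compound 1 to compound 2 (0.63 log units; beyond the scatter), a substituted nitrogen need not lose much, so a large move to a lower number is expected. The expected step is an at least 16-fold lower number from compound 3 to compound 4 (1.22 log units; beyond the scatter). For compound 4 the estimated value is 600 nM, with an expected range of 120 nM to 5000 nM.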

Compound 4, half-maximal inhibitory concentration: 4900 nM
Compound 4: the middle estimate sits 8.2-fold (0.91 log units) below what was measured; the measured number falls inside the stated range.
By their numbers in this assay, from the lowest: compound 1; then compound 2; then compound 4. At a limit, above all of these: compound 3.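

In this assay, a 2-(dimethylamino)ethyl group on the aromatic nitrogen also falls well short of the free nitrogen, with a 44-fold higher number from compound 1 to compound 4 (1.64 log units; beyond the scatter), so the large losses at this position are not limited to a chain ending in carboxy. Carboxymethyl remains the best of the substituents shown, with a 10-fold higher number from compound 2 to compound 4 (1.01 log units; beyond the scatter), though that step changes both chain length and end group. With an at least 2.0-fold lower number from compound 3 to compound 4 (0.30 log units; that floor lies within the scatter), the exchange of carboxy for dimethylamino has no firm size, because one end of the step is a limit: the limit of > 10000 nM in this assay, at which 1 of the 4 values shown sits.

These compounds do not separate chain length from end group. (dimethylamino)methyl on the same nitrogen would address this directly. As far as these compounds go, whether a small neutral group such as 2-hydroxyethyl or a plain methyl would fare better than the amine and the carboxylic acid also remains open.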